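Adding a Methanesulfonamido Group to a Biphenyl Thromboxane Antagonist

The source may report more compounds than this note shows. Statements on the series, on what has been measured and on what is new or still open speak of the compounds shown alone.

Compound 1 `O=C(O)CC/C=C\CO[C@H]1[C@@H](OCc2ccc(-c3ccccc3CO)cc2)CC[C@@H]1N1CCCCCC1` gives 1.59 nM in a functional assay on blood for antagonist activity at thromboxane A2 receptor (Homo sapiens); on this read-out lower numbers stand for tighter binding and higher numbers for weaker binding.
Compound 2 `CS(=O)(=O)Nc1ccccc1-c1ccc(COC2CC[C@H](N3CCCCCC3)[C@H]2OC/C=C\CCC(=O)O)cc1` gives 10 nM in this assay.
Compound 3 `O=C(O)CC/C=C\CO[C@H]1[C@@H](OCc2ccc(-c3ccccc3)cc2)CC[C@@H]1N1CCCCCC1` gives 5.01 nM in this assay.

Compound 3 stands second highest of the three numbers. Its nearest neighbour is compound 2, whose value lies within the scatter of that of compound 3, so no order can be read between these two; the furthest is compound 1, which sits beyond the scatter below it. Among the measured compounds shown here, the one fully measured step here, a 3.2-fold higher number from compound 1 to compound 3 (0.50 log units; beyond the scatter), removes a hydroxymethyl and leaves a bare phenyl, giving a modest loss.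

Compound 4 `CS(=O)(=O)Nc1ccccc1-c1ccc(CO[C@H]2CC[C@H](N3CCCCCC3)[C@H]2OC/C=C\CCC(=O)O)cc1` differs from compound 3 by methanesulfonamido in place of hydrogen on an aromatic carbon. For the measured compounds named here, no measured step covers this exact change. What bears on it is the pair compound 3 and compound 2: compound 2 carries the same methanesulfonamido group on the same phenyl, and its value and that of compound 3 lie within the scatter of each other. On this basis the step of a 1.4-fold higher number from compound 3 to compound 4 (0.15 log units; within the scatter) is expected to be small, with no change beyond the scatter in either direction. Compound 4 is therefore estimated to give 7 nM, within a range of 3 nM to 20 nM, in this assay.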

Compound 4, dissociation constant: 6.31 nM
The estimate for compound 4 lay 1.1-fold (0.05 log units) above the measured number, and the stated range covers the measured number.
By their numbers in this assay, from the lowest: compound 1; then compounds 3, 4 and 2 (each within the scatter of the next).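

In this assay, the change of phenyl to 2-(methanesulfonamido)phenyl can now be read on a single defined pair, and a 1.3-fold higher number from compound 3 to compound 4 (0.10 log units; within the scatter) shows that a methanesulfonamido group ortho to a large group is tolerated without a change that can be told from the scatter. Set against the hydroxymethyl group on the same aromatic carbon, the picture differs: a 4.0-fold higher number from compound 1 to compound 4 (0.60 log units; beyond the scatter), a step that, like a 3.2-fold higher number from compound 1 to compound 3 (0.50 log units; beyond the scatter), lies beyond the scatter, so that of the groups compared here on this carbon only hydroxymethyl gives a lower number than the bare phenyl. The pair with the same atoms and bonds shows a 1.6-fold lower number from compound 2 to compound 4 (0.20 log units; within the scatter), so no effect of drawing the configuration can be read, and the only thing that separates the two is: the fact that one of compounds 2 and 4 is drawn with a defined configuration and the other without, at the place where they differ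

As far as these compounds go, what an amine or a longer hydroxyalkyl chain on this aromatic carbon would give, and so whether the low number of compound 1 is particular to hydroxymethyl, stays open. Also open, from the compounds shown here alone, is whether the hydroxymethyl step would hold with a shorter carboxylic acid chain on the core.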